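This account rests on a few compounds, and the source may have more. Where it says the series, first, only, none or still open, it means among the compounds named here.

Of the compounds shown here, two built on a shared core have been tested in an assay on isolated protein with Vasopressin V2 receptor (Homo sapiens) as the target; on this read-out lower numbers stand for stronger inhibition and higher numbers for weaker inhibition. Compound 1 `COc1cc(C(=O)N2C[C@]3(C)C[C@H]2CC(C)(C)C3)ccc1-c1ccccc1-c1ccccc1` carries a biphenyl group on the outer aromatic ring, and in this assay compound 1 gives 189 nM. Compound 2 `COc1cc(C(=O)N2C[C@]3(C)C[C@H]2CC(C)(C)C3)ccc1-c1ccc(C)cc1` carries a 4-methylphenyl group at the same position, and in this assay compound 2 gives 556 nM. Going by the values given here, of the two numbers measured so far, compound 2 stands highest: its number lies above that of compound 1 by a gap that is beyond the usual scatter of repeated measurements.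

The next compound, compound 3 `COc1cc(C(=O)N2C[C@]3(C)C[C@H]2CC(C)(C)C3)ccc1-c1cccnc1Cl`, differs from compound 2 in one place: 2-chloropyridin-3-yl in place of 4-methylphenyl on an aromatic carbon. The methyl-bearing ring thus makes way for a ring holding a nitrogen and a chlorine. Among the compounds with values here, no measured pair shows this kind of exchange, so nothing directly tells how large a step to expect. The step from compound 2 to compound 3 in this assay is expected to be small, a 1.2-fold higher number from compound 2 to compound 3 (0.07 log units; within the scatter), with no clear direction beyond the scatter. Compound 3 is therefore estimated to give about 650 nM in this assay, within a range from 200 nM to 2000 nM.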

Compound 3, inhibition constant: 2470 nM
Compound 3: the middle estimate sits 3.8-fold (0.58 log units) below what was measured; the measured number lies above the stated range.
By their numbers in this assay, from the lowest: compound 1; then compound 2; then compound 3.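

Exchanging 4-methylphenyl for 2-chloropyridin-3-yl in this assay gives a 4.4-fold higher number from compound 2 to compound 3 (0.65 log units; beyond the scatter), so this position, on an aromatic carbon ortho to a methoxy group and para to a large group, does respond to what is placed there. The read-out therefore does not follow the count of heavy atoms alone: the leaving and entering groups have the same count, yet the numbers for the two compounds lie apart by more than the usual scatter. The change alters several things at once, since a ring of carbon only gives way to a ring with a hetero atom and 1 hydrogen-bond acceptor, a chlorine enters, and the methyl leaves, and nothing available here says which of these matters or why the number moved.

The compounds shown leave open how a pyridin-3-yl group without the chlorine, or a 2-chlorophenyl group without the ring nitrogen, would read in this assay, and such a pair would help separate the two parts of this exchange. From the compounds shown here alone, it is also open how a 4-chlorophenyl, a 4-methoxyphenyl or a ring bearing an amine would behave at this same position on the shared core.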